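The compounds below may be only part of what the source reports. "The series", "measured", "known", "first", "only" and "open" are said of these compounds alone.

Measured compounds in a functional assay on MGC-803 cells (Homo sapiens) for cytotoxicity, read by MTT assay, with a stated time of 72 h; on this read-out higher numbers stand for weaker inhibition and lower numbers for stronger inhibition:
compound 1, `O=C1C(=Cc2ccc(Cl)cc2)C(=O)N(c2ccc(Cl)cc2)N1c1ccc(Cl)cc1` — 32600 nM
compound 2, `O=C1C(=Cc2ccc(Cl)cc2Cl)C(=O)N(c2ccc(Cl)cc2)N1c1ccc(Cl)cc1` — > 128000 nM
compound 3, `O=C1C(=Cc2ccc(F)cc2F)C(=O)N(c2ccc(Cl)cc2)N1c1ccc(Cl)cc1` — 35700 nM

Among these, compound 1 stands lowest of the two numbers given, with compound 3 nearest at 35700 nM. For compound 2 the assay gives only a limit, > 128000 nM, so its number is not known (the limit of > 128000 nM in this assay, at which 1 of the 3 values shown sits).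

Compound 4, `O=C1C(=C/C=C/c2ccccc2)C(=O)N(c2ccc(Cl)cc2)N1c1ccc(Cl)cc1`, differs from compound 1 at one place: 2-phenylethenyl in place of 4-chlorophenyl on a double-bonded chain carbon bound to a double-bonded ring carbon. The step of a 1.1-fold higher number from compound 1 to compound 3 (0.04 log units; within the scatter) changes the same place and stays within the scatter, whereas an at least 3.9-fold higher number from compound 1 to compound 2 (0.59 log units; beyond the scatter) and an at least 3.5-fold lower number from compound 2 to compound 3 (0.55 log units; beyond the scatter) show that a second chloro at that place pushes the value beyond the scatter. Among the measured compounds shown here, the change to compound 4 replaces the chlorinated ring with an unsubstituted 2-phenylethenyl group, so no step beyond the scatter is expected, with the nearest precedent being compound 3. Compound 4 is therefore estimated at 35000 nM, between 14000 nM and 90000 nM, which would mean an expected step of a 1.1-fold higher number from compound 1 to compound 4 (0.03 log units; within the scatter).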

Compound 4, half-maximal inhibitory concentration: 5100 nM
Compound 4: middle estimate off by 6.9-fold (0.84 log units), on the high side, outside the stated range (below it).
By their numbers in this assay, from the lowest: compound 4; then compounds 1 and 3 (each within the scatter of the next). At a limit, above all of these: compound 2.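

In this assay, no earlier group at this place, on a double-bonded chain carbon bound to a double-bonded ring carbon, had given a number clearly lower than those of compound 1 and compound 3, but 2-phenylethenyl does, with a 6.4-fold lower number from compound 1 to compound 4 (0.81 log units; beyond the scatter) and a 7.0-fold lower number from compound 3 to compound 4 (0.85 log units; beyond the scatter). The gap is wider against the dichlorinated compound, with an at least 25-fold lower number from compound 2 to compound 4 (1.39 log units; beyond the scatter). That step starts from a limit of the assay for compound 2, not from a number: the limit of > 128000 nM in this assay, at which 1 of the 4 values shown sits.

Compound 4 both gains a double bond outside aromatic rings and loses the chloro, so the compounds shown cannot separate these two changes. Also open, as far as these compounds go, is whether a longer chain at this place, or an amine on the ring of the 2-phenylethenyl group, would keep the lower number.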